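Cyclopentyl for tert-Butyl on the Side Chain of Compound 3

The source may hold more compounds than are shown below. What is called first, only, known or untested is meant among the compounds shown, and "the series" means these compounds.

The measured compounds are compound 1 `CC(C)CCn1nc(C2CCCC2)c(O)c(C2=NS(=O)(=O)c3cc(NS(C)(=O)=O)ccc3N2)c1=O`, compound 2 `CCC(C)(C)c1nn(CCC(C)C)c(=O)c(C2=NS(=O)(=O)c3cc(NS(C)(=O)=O)ccc3N2)c1O` and compound 3 `CC(C)(C)CCn1nc(-c2cccs2)c(O)c(C2=NS(=O)(=O)c3cc(NS(C)(=O)=O)ccc3N2)c1=O`. In an in vitro ADME assay on microsomes from liver (Homo sapiens) for metabolic stability, tested at 5 uM (a lower number here means that the compound disappears faster, a higher number that the compound lasts longer), compound 1 gives 0.283 h. Compound 2 gives 0.1 h. For compound 3 the assay reports only a limit, > 1 h.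

Compound 3 therefore stands at the limit of > 1 h in this assay, at which 1 of the 3 values shown sits, and its number is not known, only that it lies beyond the range the assay resolves. Compound 4 `CS(=O)(=O)Nc1ccc2c(c1)S(=O)(=O)N=C(c1c(O)c(-c3cccs3)nn(CCC3CCCC3)c1=O)N2` differs from compound 3 by cyclopentyl in place of tert-butyl on a saturated chain carbon, two bonds along the chain from an aromatic nitrogen.

Within the data shown here, one measured step bears on this change: a 2.8-fold lower number from compound 1 to compound 2 (0.45 log units; beyond the scatter), a modest step that runs from cyclopentyl to a branched alkyl group, the reverse of the present direction, and on an aromatic carbon rather than a chain carbon. Taken loosely, it points toward a number for compound 4 that is no lower than that of compound 3, and compound 3 itself offers no number to move from. The step is expected to be a step that the limit leaves unreadable from compound 3 to compound 4, within the scatter. Compound 4 is therefore expected to give 1.2 h, with a range from 0.5 h to 3 h.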

Compound 4, half-life: > 1 h
Compound 4: no number, only a limit; the forecaster's own chance of this, stated with the estimate: 55%; the middle value lies beyond the limit too.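

In this assay compound 3 gives > 1 h, a limit and not a number. Compound 4 gives > 1 h, also a limit, so no step can be read between compound 3 and compound 4. The compounds shown leave open whether cyclopentyl in place of tert-butyl changes the half-life at all.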